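Removing the aminoalkyl chain from compound 1

The source may report more compounds than this note shows. Statements on the series, on what has been measured and on what is new or still open speak of the compounds shown alone.

Compound 1 `COc1ccc(C(c2ccc(OC(C)CN(C)C)cc2)c2cccc3ccccc23)c(OC)c1OC`: 8410 nM
Compound 2 `C=CCC(O)(c1ccc(OC)c(OC)c1OC)c1cccc2ccccc12`: > 20000 nM
Compound 3 `CCOC(=O)/C=C/CO/N=C(/c1ccc(OC)c(OC)c1OC)c1cccc2ccccc12`: > 20000 nM

For the measured compounds named here, in a functional assay on HCT-116 cells (Homo sapiens) for inhibition, read by sulforhodamine B assay, with a stated time of 48 h (a lower number here means a stronger inhibitor, a higher number a weaker inhibitor), compound 1 gives 8410 nM, the only number among the three measured compounds. Compound 2 reaches only a limit of the assay, > 20000 nM. Compound 3 likewise reaches only a limit, > 20000 nM. Two of the three values sit at the limit of > 20000 nM in this assay, at which 2 of the 3 values shown sit, so compound 1 is the one measured point from which to start.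

Compound 4 `COc1ccc(C(c2ccc(O)cc2)c2cccc3ccccc23)c(OC)c1OC` differs from compound 1 in one place: hydrogen in place of 1-((dimethylamino)methyl)ethyl on an oxygen on an aromatic ring. Going by the values given here, no measured pair shows this change, so its effect is open. The step from compound 1 to compound 4 in this assay is expected to be modest, toward weaker inhibition, at a 1.8-fold higher number from compound 1 to compound 4 (0.25 log units; within the scatter). Compound 4 is therefore estimated at 15000 nM, within 4000 nM to 40000 nM.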

Compound 4, half-maximal inhibitory concentration: 16000 nM
For compound 4 the middle estimate is 1.1-fold (0.03 log units) below the measured one; the range from low to high includes it.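

Hydrogen in place of 1-((dimethylamino)methyl)ethyl on an oxygen on an aromatic ring gives a 1.9-fold higher number from compound 1 to compound 4 (0.28 log units; within the scatter) in this assay and provides the first comparison of two compounds that differ in one place. At this position, the whole chain can therefore be replaced by hydrogen without a step beyond the scatter.

From the compounds shown here alone, whether a methoxy group, a carboxylic acid or a longer amine chain on this oxygen would give a stronger or weaker inhibitor stays open. Any step toward weaker inhibition from compound 4 would soon meet a limit of the assay: the limit of > 20000 nM in this assay, at which 2 of the 4 values shown sit.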